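Cyclopropyl to difluoromethyl on the pyridine of compound 3

The compounds below may be only part of what the source reports. "The series", "measured", "known", "first", "only" and "open" are said of these compounds alone.

Of the compounds shown here, three sharing one core have been tested in an assay on T-REx-293 cells for inhibition of potassium channel subfamily T member 1 (Homo sapiens), read by patch clamp; a lower number here means a stronger inhibitor, a higher number a weaker inhibitor. Compound 1 `Cc1cccc(-c2noc([C@H](C)NC(=O)c3cc(C(F)(F)F)nn3C)n2)n1` reached only the limit of > 30000 nM in this assay. Compound 2 `Cc1cc(-c2noc([C@H](C)NC(=O)c3cc(C(F)(F)F)nn3C)n2)ccn1` gives 165 nM in this assay. Compound 3 `C[C@H](NC(=O)c1cc(C(F)(F)F)nn1C)c1nc(-c2ccnc(C3CC3)c2)no1` gives 16 nM in this assay, the lowest number among the measured values, and a 10-fold lower number from compound 2 to compound 3 (1.01 log units; beyond the scatter) separates it from its nearest neighbour. Compound 4 `C[C@H](NC(=O)c1cc(C(F)(F)F)nn1C)c1nc(-c2ccnc(C(F)F)c2)no1` is not yet measured. It differs from compound 3 by difluoromethyl in place of cyclopropyl on an aromatic carbon. The measured step touching this ring carbon is a 10-fold lower number from compound 2 to compound 3 (1.01 log units; beyond the scatter), where cyclopropyl in place of methyl lowered the number sharply, and an at least 1800-fold lower number from compound 1 to compound 3 (3.27 log units; beyond the scatter) shows how far this substitution pattern has moved from compound 1. For the measured compounds named here, no measured step tells what difluoromethyl does at this carbon, so the outcome is uncertain. The expected step is a 2.5-fold higher number from compound 3 to compound 4 (0.40 log units; beyond the scatter), a moderate rise that stays well short of the number of compound 2. Compound 4 is therefore estimated at 40 nM in this assay, with a range from 10 nM to 160 nM.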

Compound 4, half-maximal inhibitory concentration: 61 nM
The estimate for compound 4 lay 1.5-fold (0.18 log units) below the measured number, and the stated range covers the measured number.
By their numbers in this assay, from the lowest: compound 3; then compound 4; then compound 2. At a limit, above all of these: compound 1.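

In this assay, difluoromethyl on the ring carbon next to the ring nitrogen gives back part of what cyclopropyl gained, with a 3.8-fold higher number from compound 3 to compound 4 (0.58 log units; beyond the scatter) marking the loss, yet it still keeps an edge over methyl, with a 2.7-fold lower number from compound 2 to compound 4 (0.43 log units; beyond the scatter) marking that gain. This carbon therefore accepts a fluorine-bearing group, and compound 3, compound 4 and compound 2 now form an order of cyclopropyl, difluoromethyl and methyl, each separated beyond the usual scatter. The remaining step, an at least 490-fold lower number from compound 1 to compound 4 (2.69 log units; beyond the scatter) as printed, is large but gives only a bound and not an exact size, because one end of it is a limit: the limit of > 30000 nM in this assay, at which 1 of the 4 values shown sits.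

Three groups at this carbon do not reveal what sets their order. Trifluoromethyl, methoxy or an amine here would test that order further, and whether it holds with other changes to the shared core remains open.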